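The compounds below may be only part of what the source reports. "The series", "measured", "known", "first", "only" and "open" are said of these compounds alone.

Measured compounds:
Compound 1 `Cc1cc(Cl)ccc1Nc1ncc(C(F)(F)F)c(N2Cc3cccc(N(C)S(C)(=O)=O)c3C2)n1` gives 17400 nM in a functional assay on HeLa cells (Homo sapiens) for antiproliferative activity, read by spectrophotometry, with a stated time of 2 days; a higher number here means a weaker inhibitor of growth, a lower number a stronger inhibitor of growth.
Compound 2 `CN(c1cccc2c1CN(c1nc(Nc3ccc(Cl)c(C(F)(F)F)c3)ncc1C(F)(F)F)C2)S(C)(=O)=O` gives 11100 nM in this assay.
Compound 3 `COc1cc(Nc2ncc(C(F)(F)F)c(N3Cc4cccc(N(C)S(C)(=O)=O)c4C3)n2)c(OC)cc1Cl` gives 16500 nM in this assay.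

Compound 3 holds the second highest of these three numbers, and all three sit within the scatter of one another. Compound 4 `CN(c1cccc2c1CN(c1nc(Nc3cc(Cl)cc(C(F)(F)F)c3)ncc1C(F)(F)F)C2)S(C)(=O)=O` differs from compound 3 in one place: 3-chloro-5-(trifluoromethyl)phenyl in place of 4-chloro-2,5-dimethoxyphenyl on a nitrogen on an aromatic ring. The measured steps that bear on this are a 1.5-fold higher number from compound 2 to compound 3 (0.17 log units; within the scatter) and a 1.1-fold lower number from compound 1 to compound 3 (0.02 log units; within the scatter), each within the scatter; swapping the substituted phenyl ring has so far moved nothing beyond it. Compound 4 carries the same chlorine and trifluoromethyl pattern as compound 2, so the step of a 1.4-fold lower number from compound 3 to compound 4 (0.14 log units; within the scatter) is expected to stay within the scatter. For compound 4 the estimate is 12000 nM, with a range from 5000 nM to 30000 nM.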

Compound 4, concentration for 50% growth inhibition: 4300 nM
Beside the measured number, compound 4's estimate is 2.8-fold (0.45 log units) above it; measured number below the stated range.
By their numbers in this assay, from the lowest: compound 4; then compounds 2, 3 and 1 (each within the scatter of the next).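

At the nitrogen on an aromatic ring, changing the phenyl group can move the number in this assay beyond the scatter, as the 3-chloro-5-(trifluoromethyl)phenyl group shows in three steps (a 3.8-fold lower number from compound 3 to compound 4 (0.58 log units; beyond the scatter)) (a 4.0-fold lower number from compound 1 to compound 4 (0.61 log units; beyond the scatter)) (a 2.6-fold lower number from compound 2 to compound 4 (0.41 log units; beyond the scatter)). The last step is the most telling: both groups carry one chlorine and one trifluoromethyl, so the arrangement on the ring matters and not just their presence. No measurement at hand explains this.

Still open, as far as these compounds go, is whether a nitrile or a carboxylic acid could replace that trifluoromethyl with the number holding. From the compounds shown here alone, whether the chlorine is needed at all also remains open.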